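This account rests on a few compounds, and the source may have more. Where it says the series, first, only, none or still open, it means among the compounds named here.

Among the measured compounds shown here, compound 1 `Cn1c(-c2ccc(NC(=O)CSc3nc4cc(Cl)ccc4o3)cc2)nc(-c2ccccc2)c1-c1ccccc1` is one of three compounds measured in a functional assay on HT-29 cells (Homo sapiens) for cytotoxicity, read by MTT assay, with a stated time of 24 h (a higher number here means a weaker inhibitor, a lower number a stronger inhibitor), where compound 1 gives 20.6 ug/mL, the second highest of the three numbers. Compound 2 `Cc1ccc2oc(SCC(=O)Nc3ccc(-c4nc(-c5ccccc5)c(-c5ccccc5)n4C)cc3)nc2c1` gives 22.4 ug/mL, and compound 3 `Cn1nnnc1SCC(=O)Nc1ccc(-c2nc(-c3ccccc3)c(-c3ccccc3)n2C)cc1` gives 1.6 ug/mL. Compound 4 `Cc1nnc(SCC(=O)Nc2ccc(-c3nc(-c4ccccc4)c(-c4ccccc4)n3C)cc2)s1` has not yet been measured; it differs from compound 1 in one place: 5-methyl-1,3,4-thiadiazol-2-yl in place of 5-chloro-1,3-benzoxazol-2-yl on a sulfur. For the measured compounds named here, the steps that bear on this change are those that replace the 1,3-benzoxazol-2-yl ring on the sulfur with a five-membered aromatic ring with 3 hetero atoms, a 13-fold lower number from compound 1 to compound 3 (1.11 log units; beyond the scatter) and a 14-fold lower number from compound 2 to compound 3 (1.15 log units; beyond the scatter), both large, whereas a 1.1-fold higher number from compound 1 to compound 2 (0.04 log units; within the scatter). Because a 13-fold lower number from compound 1 to compound 3 (1.11 log units; beyond the scatter) and a 14-fold lower number from compound 2 to compound 3 (1.15 log units; beyond the scatter) when a five-membered aromatic ring with 3 hetero atoms enters on the sulfur, and compound 4 also carries such a ring on the sulfur, a clearly lower number is expected for compound 4, an 8.2-fold lower number from compound 1 to compound 4 (0.92 log units; beyond the scatter). Compound 4 is accordingly estimated at 2.5 ug/mL, within 0.8 ug/mL to 8 ug/mL.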

Compound 4, half-maximal inhibitory concentration: 2.7 ug/mL
Compound 4: middle estimate off by 1.1-fold (0.03 log units), on the low side, and the stated range covers the measured number.
By their numbers in this assay, from the lowest: compounds 3 and 4 (each within the scatter of the next); then compounds 1 and 2 (each within the scatter of the next).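

In this assay, 5-methyl-1,3,4-thiadiazol-2-yl on the sulfur gives a 7.6-fold lower number from compound 1 to compound 4 (0.88 log units; beyond the scatter) and an 8.3-fold lower number from compound 2 to compound 4 (0.92 log units; beyond the scatter), so among these compounds a lower number is no longer tied to 1-methyl-1H-tetrazol-5-yl alone. The remaining comparison, a 1.7-fold higher number from compound 3 to compound 4 (0.23 log units; within the scatter), lies within the scatter, so these two groups are not told apart here. Nothing measured here explains these steps. The compounds shown leave open how an ethyl chain or a carboxylic acid on the sulfur would read, and what the methyl of 5-methyl-1,3,4-thiadiazol-2-yl contributes.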